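This account rests on a few compounds, and the source may have more. Where it says the series, first, only, none or still open, it means among the compounds named here.

Measured compounds:
compound 1 `CN1CCCc2ccc(NC(=O)c3ccc(-c4ccccc4)cc3)cc21` — 7.5
compound 2 `CN1CCCc2ccc(NC(=O)c3cccc(-c4ccccc4)c3)cc21` — < 6.8
compound 3 `CC(=O)c1cccc(-c2ccc(C(=O)Nc3ccc4c(c3)N(C)CCC4)cc2)c1` — 7

In a functional assay for antagonist activity at transient receptor potential cation channel subfamily V member 1 (Homo sapiens), read by FLIPR and calcium flux (on this read-out lower numbers stand for lower potency and higher numbers for higher potency (the scale is a negative logarithm)), compound 3 gives 7, the lowest of the two numbers shown; compound 1 gives 7.5. For compound 2 the value of < 6.8 is a limit of the assay and not a number (the limit of < 6.8 in this assay, at which 1 of the 3 values shown sits). Compound 4 `CNS(=O)(=O)c1cccc(-c2ccc(C(=O)Nc3ccc4c(c3)N(C)CCC4)cc2)c1` differs from compound 3 in one place: methylsulfamoyl in place of acetyl on an aromatic carbon. Among the compounds with values here, only one measured step bears on this position, a number 0.50 log units lower from compound 1 to compound 3 (beyond the scatter), a modest loss on placing a group there. A further change of group at the same carbon is therefore expected to shift potency little, if anything downward. Compound 4 is expected to give 6.9 (from 6.3 to 7.5), a step of a number 0.10 log units lower from compound 3 to compound 4 (within the scatter) that stays within the scatter.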

Compound 4, negative logarithm of the antagonist equilibrium constant: 7
Compound 4: the middle estimate sits 0.10 log units below what was measured; low and high end bracket the measured number.
By their numbers in this assay, from the lowest: compounds 3 and 4 (each within the scatter of the next); then compound 1. At a limit, below all of these: compound 2.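

In this assay, methylsulfamoyl in place of acetyl on this aromatic carbon makes no measurable difference (no change at the digits printed from compound 3 to compound 4 (within the scatter)). Methylsulfamoyl in place of hydrogen costs a modest amount (a number 0.50 log units lower from compound 1 to compound 4 (beyond the scatter)), so two different groups at this carbon now stand below the unsubstituted compound 1, and the swap between them does not recover the loss. Nothing in hand gives a cause for this result. From the compounds shown here alone, whether an amine or a carboxylic acid on the same carbon would fit this picture stays open.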